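Sulfonyl aryl exchange on the shared core: working notes

This account rests on a few compounds, and the source may have more. Where it says the series, first, only, none or still open, it means among the compounds named here.

Compound 1 `COc1ccc(-c2cc(=O)c3c(OC)cc(OC)cc3n2S(=O)(=O)c2c(F)c(F)c(F)c(F)c2F)cc1` in an ADME assay on BJ cells (Homo sapiens) for antiproliferative activity, with a stated time of 72 h (a higher number here means that more compound is needed for the effect, a lower number that less compound is needed), gives > 34400 nM, a limit of the assay.
Compound 2 `COc1ccc(-c2cc(=O)c3c(OC)cc(OC)cc3n2S(=O)(=O)c2cccc(Br)c2)cc1` in this assay gives > 58600 nM, again a limit of the assay.

Compound 2 thus stands at the upper edge of what this assay can report; its value is not a number. Of the two values shown, one sits at the limit of > 34400 nM in this assay, at which 1 of the 2 values shown sits, and the other at the limit of > 58600 nM in this assay, at which 1 of the 2 values shown sits, so neither compound can be placed relative to the other, and the step that the two limits leave unreadable from compound 1 to compound 2 cannot be read in size or direction. The aryl group on the sulfonyl sulfur therefore has no measured effect on record in this series.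

Compound 3 `COc1ccc(-c2cc(=O)c3c(OC)cc(OC)cc3n2S(=O)(=O)c2ccc(C)cc2)cc1` differs from compound 2 by 4-methylphenyl in place of 3-bromophenyl on a sulfonyl sulfur. Going by the values given here, the only measured step at this position is the unreadable one from compound 1 to compound 2, so no size of step is supported by the data; the two limits point to another limit rather than to a number. Compound 3 is expected at 60000 nM, between 20000 nM and 200000 nM. The step that the limit leaves unreadable from compound 2 to compound 3 is expected to be formal only, not a readable change.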

Compound 3, half-maximal effective concentration: > 44800 nM
Compound 3: no number, only a limit (the forecaster's own chance of this, stated with the estimate: 85%); the middle value does not contradict the limit.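

In this assay compound 3 gives > 44800 nM, a limit of the assay. Going by these compounds alone, compound 1, compound 2 and compound 3 all carry limits, so no step among them can be read in size or direction. The compounds shown leave open whether any aryl group on the sulfonyl sulfur of the shared core gives a measurable half-maximal effective concentration, and how these three aryl groups rank.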